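From 4-methoxyphenyl to pyridin-2-yl on the shared core

The source may report more compounds than this note shows. Statements on the series, on what has been measured and on what is new or still open speak of the compounds shown alone.

In a functional assay on A549 cells (Homo sapiens) for antiproliferative activity, read by MTT assay, with a stated time of 48 h (on this read-out higher numbers stand for weaker inhibition and lower numbers for stronger inhibition), compound 1 `O=C(/C=C/c1ccc(O)c(O)c1)N1CCN(c2ccccc2F)CC1` gives 1.43 ug/mL, compound 2 `O=C(/C=C/c1ccc(O)c(O)c1)N1CCN(c2cccc(Cl)c2)CC1` gives 1.29 ug/mL and compound 3 `COc1ccc(N2CCN(C(=O)/C=C/c3ccc(O)c(O)c3)CC2)cc1` gives 0.93 ug/mL. Compound 3 stands level with the other two. The measured steps are a 1.4-fold lower number from compound 2 to compound 3 (0.14 log units; within the scatter), a 1.5-fold lower number from compound 1 to compound 3 (0.19 log units; within the scatter) and a 1.1-fold lower number from compound 1 to compound 2 (0.04 log units; within the scatter). Compound 4 `O=C(/C=C/c1ccc(O)c(O)c1)N1CCN(c2ccccn2)CC1` carries pyridin-2-yl in place of 4-methoxyphenyl on an amine nitrogen in a ring. All three measured steps changed this same group, but none brought in a ring with a hetero atom, so they offer only limited guidance. On that evidence, no step beyond the scatter is expected, in either direction. The expected step is a 1.4-fold higher number from compound 3 to compound 4 (0.15 log units; within the scatter). The estimate for compound 4 is 1.3 ug/mL, with an expected range from 0.6 ug/mL to 3 ug/mL.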

Compound 4, half-maximal inhibitory concentration: 2.32 ug/mL
Compound 4: middle estimate off by 1.8-fold (0.25 log units), on the low side, and the stated range covers the measured number.
By their numbers in this assay, from the lowest: compounds 3, 2, 1 and 4 (each within the scatter of the next, the first and the last beyond it).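

In this assay, going by these compounds alone, the pyridin-2-yl ring is the first change at this position to give a step beyond the scatter, and it does so against one compound only: the step is a 2.5-fold higher number from compound 3 to compound 4 (0.40 log units; beyond the scatter), whereas it is a 1.8-fold higher number from compound 2 to compound 4 (0.25 log units; within the scatter) and a 1.6-fold higher number from compound 1 to compound 4 (0.21 log units; within the scatter). Compound 4 thus separates from compound 3 but not from the 3-chlorophenyl or 2-fluorophenyl compounds. No measurement shown bears on the reason for this step. The compounds shown leave open whether the step follows the ring nitrogen or the loss of the methoxy group, a question that an unsubstituted phenyl or a pyridin-4-yl group on the same nitrogen would address.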